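From methyl to benzyloxycarbonyl on a shared core

The source may hold more compounds than are shown below. What is called first, only, known or untested is meant among the compounds shown, and "the series" means these compounds.

Measured in a functional assay on HeLa cells (Homo sapiens) for antiproliferative activity, read by MTT assay, with a stated time of 48 h; a lower number here means a stronger inhibitor, a higher number a weaker inhibitor:
Compound 1 `Brc1ccc2[nH]c(-c3cn(-c4ccccc4)nc3-c3ccccc3)nc2c1`: 1760 nM
Compound 2 `Cc1ccc2[nH]c(-c3cn(-c4ccccc4)nc3-c3ccccc3)nc2c1`: 6560 nM

Of these two, compound 2 has the higher number, which makes it the weaker inhibitor. Compound 3 `O=C(OCc1ccccc1)c1ccc2[nH]c(-c3cn(-c4ccccc4)nc3-c3ccccc3)nc2c1` keeps the shared core and changes one group, with benzyloxycarbonyl in place of methyl on an aromatic carbon. Within the data shown here, only one measured step bears on this place: a 3.7-fold higher number from compound 1 to compound 2 (0.57 log units; beyond the scatter), a modest change on going from bromo to methyl. It shows that the number responds to the group on this carbon. However, neither bromo nor methyl resembles benzyloxycarbonyl, so the step guides size better than direction. A similarly modest step is therefore expected in this assay, leaning tentatively towards a lower number, though the opposite direction remains possible. The expected change is a 2.2-fold lower number from compound 2 to compound 3 (0.34 log units; beyond the scatter). For compound 3 the estimated value is 3000 nM, with an expected range of 800 nM to 10000 nM.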

Compound 3, half-maximal inhibitory concentration: 21300 nM
Compound 3: middle estimate off by 7.1-fold (0.85 log units), on the low side; the measured number lies above the stated range.
By their numbers in this assay, from the lowest: compound 1; then compound 2; then compound 3.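

In this assay, benzyloxycarbonyl in place of methyl gives a 3.2-fold higher number from compound 2 to compound 3 (0.51 log units; beyond the scatter), so this much larger group, with its added aromatic ring and two hydrogen-bond acceptors, goes with a weaker inhibitor rather than a stronger one. Set against bromo, the change is greater, at a 12-fold higher number from compound 1 to compound 3 (1.08 log units; beyond the scatter), which shows that the choice of group on this one carbon can produce a large step and not just a modest one. Nothing available here explains the order of these three groups.

As far as these compounds go, whether the weakening follows the size of the group or something specific to benzyloxycarbonyl stays open. A carboxylic acid or an amine on the same carbon would show whether a small group carrying oxygen or nitrogen sits closer to bromo or to benzyloxycarbonyl.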